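A few compounds are considered here, and "the series" means these few. Any claim that something is new, unique, unknown or untested is made for them only; others in the source may bear on it.

Measured in an ADME assay on MT4 cells (Homo sapiens) for cytotoxicity, read by MTT assay, with a stated time of 4 days; a higher number here means that more compound is tolerated, a lower number that less compound is tolerated:
- Compound 1 `CC(C)N(C)c1nc(Cc2c(F)cccc2F)cc(=O)[nH]1`: 85000 nM
- Compound 2 `CCCN(C)c1nc(Cc2c(F)cccc2F)cc(=O)[nH]1`: 85000 nM
- Compound 3 `O=c1cc(Cc2c(F)cccc2N2CCCC2)nc(N2CCCC2)[nH]1`: > 73000 nM, a limit

Compound 2 stands level with compound 1 at the digits shown, and no other compound gives a number to set against it. Compound 3 gives only a limit, > 73000 nM, as the limit of > 73000 nM in this assay, at which 1 of the 3 values shown sits, records. Compound 4 `CC1CCCCN1c1nc(Cc2c(F)cccc2F)cc(=O)[nH]1` carries a new amine on the shared core: 2-methylpiperidin-1-yl in place of methyl(propyl)amino on an aromatic carbon. The group is 2-methylpiperidin-1-yl in place of methyl(propyl)amino on an aromatic carbon, between two ring nitrogen atoms.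

Going by the values given here, the one measured step that bears on this change is no change at the digits printed from compound 1 to compound 2 (within the scatter). It also alters the amine on that carbon, though only from isopropyl to propyl, so it is a modest guide to a change that brings in a ring. On that evidence, no shift beyond the scatter is expected in this assay. The expected step is a 1.1-fold lower number from compound 2 to compound 4 (0.05 log units; within the scatter). For compound 4 the estimate is 75000 nM, with an expected range from 35000 nM to 130000 nM.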

Compound 4, half-maximal cytotoxic concentration: > 78000 nM
Compound 4: no number, only a limit; the forecaster's own chance of this, stated with the estimate: 40%; at least 1.0-fold (0.01 log units) between middle value and limit.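

In this assay compound 4 gives only a limit, > 78000 nM. The steps to compound 4 from compound 1 and from compound 2 therefore cannot be read. The compounds shown leave open whether 2-methylpiperidin-1-yl in place of methyl(propyl)amino shifts the tolerated concentration at all.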